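Adding a chloro group to compound 3

The compounds below may be only part of what the source reports. "The series", "measured", "known", "first", "only" and "open" are said of these compounds alone.

- compound 1 `CCCS(=O)(=O)N1CCC(CNC(=O)C2CC2)(C(=O)N2CCOCC2)CC1`: < 1.4 (a limit)
- compound 2 `CCCS(=O)(=O)N1CCC(CNC(=O)c2ccc(F)cc2C(F)(F)F)(C(=O)N2CCOCC2)CC1`: < 1.4 (a limit)
- compound 3 `CCCS(=O)(=O)N1CCC(CNC(=O)c2c(F)cccc2F)(C(=O)N2CCOCC2)CC1`: < 1.4 (a limit)

In a physicochemical assay for lipophilicity (a higher number here means a more lipophilic compound, a lower number a more polar compound), compound 3 stands at < 1.4, which is a limit and not a number. It has company there, for the measurements so far show (the limit of < 1.4 in this assay, at which 3 of the 3 values shown sit).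

Compound 4 `CCCS(=O)(=O)N1CCC(CNC(=O)c2c(F)ccc(Cl)c2F)(C(=O)N2CCOCC2)CC1` turns the 2,6-difluorophenyl group of compound 3 into 3-chloro-2,6-difluorophenyl, with chloro in place of hydrogen on an aromatic carbon.

The measured steps that bear on this change are those into compound 3, and neither has a readable size. One is a step that the two limits leave unreadable from compound 1 to compound 3. The other is a step that the two limits leave unreadable from compound 2 to compound 3. The step between the other two is no clearer: a step that the two limits leave unreadable from compound 1 to compound 2. Among the compounds with values here, no measured step therefore sets the size of this one, and only a small upward move in this assay is expected, with low confidence. The expected move is a step that the limit leaves unreadable from compound 3 to compound 4. Compound 4 may well be reported as a limit too. For compound 4 the estimated value is 1.3, with an expected range from 0.9 to 1.8.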

Compound 4, partition coefficient: < 1.4
Compound 4: a limit, no number; the forecaster's own chance of this, stated with the estimate: 55%; the middle value does not contradict the limit.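

Compound 4 comes back as a limit, just as compound 1, compound 2 and compound 3 do, so none of the steps among them can be read: the limit of < 1.4 in this assay, at which 4 of the 4 values shown sit.

The compounds shown leave open how large a change chloro in place of hydrogen makes in this assay, and how these four compounds order there.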